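A longer chain on the carbonyl of compound 2

The source may report more compounds than this note shows. Statements on the series, on what has been measured and on what is new or still open speak of the compounds shown alone.

In a functional assay on HCT-116 cells (Homo sapiens) for inhibition, read by MTT assay, with a stated time of 48 h (on this read-out lower numbers stand for stronger inhibition and higher numbers for weaker inhibition), compound 1 `COc1ccc(CNc2cc(OC)c(OC)c(OC)c2)cc1[N+](=O)[O-]` gives 18200 nM, while compound 2 `COc1ccc(CN(C(C)=O)c2cc(OC)c(OC)c(OC)c2)cc1O` gives 270 nM, the lower of the two numbers by a gap beyond the scatter. Compound 3 `CC/C=C/C(=O)N(Cc1ccc(OC)c(O)c1)c1cc(OC)c(OC)c(OC)c1` differs from compound 2 by having but-1-en-1-yl in place of methyl on a carbonyl carbon. Within the data shown here, no two measured compounds differ by this change alone, so any forecast is uncertain. A modest weakening is expected, with an estimated 2.6-fold higher number from compound 2 to compound 3 (0.41 log units; beyond the scatter) in this assay. The expected value for compound 3 is 700 nM, within an estimated range of 150 nM to 3500 nM.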

Compound 3, half-maximal inhibitory concentration: 63 nM
For compound 3 the middle estimate is 11-fold (1.05 log units) above the measured one; the measured number lies below the stated range.
By their numbers in this assay, from the lowest: compound 3; then compound 2; then compound 1.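

In this assay, putting but-1-en-1-yl in place of methyl on a carbonyl carbon gives a 4.3-fold lower number from compound 2 to compound 3 (0.63 log units; beyond the scatter). Among these compounds, this is the first single-place comparison at this position, and it shows that the carbonyl carbon can carry a longer chain with a double bond and that inhibition gets stronger rather than weaker. Nothing in the data explains this gain.

Still open, going by these compounds, is whether the gain depends on the double bond or on chain length alone. A saturated butyl chain on this carbonyl carbon would separate the two, and a longer chain would test how far the trend extends.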